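The source may report more compounds than this note shows. Statements on the series, on what has been measured and on what is new or still open speak of the compounds shown alone.

Compound 3 `CC(C)(C)C(=O)N1CCC[C@H]1C(=O)N1CCC(NS(=O)(=O)c2cc(S(=O)(=O)c3ccccc3)ccc2C(F)(F)F)CC1` gives 40 nM in an assay on isolated protein for binding affinity to secreted frizzled-related protein 1 (Homo sapiens), read by fluorescence (on this read-out higher numbers stand for weaker inhibition and lower numbers for stronger inhibition), the lowest number among the three measured compounds. Compound 2 `O=C1CC[C@@H](C(=O)N2CCC(NS(=O)(=O)c3cc(S(=O)(=O)c4ccccc4)ccc3C(F)(F)F)CC2)N1` gives 90 nM in this assay, and compound 1 `CN(C)CC(=O)N1CCC(NS(=O)(=O)c2cc(S(=O)(=O)c3ccccc3)ccc2C(F)(F)F)CC1` gives 300 nM. The three measured steps each exchange the whole group on a carbonyl carbon of the shared core: a 3.3-fold lower number from compound 1 to compound 2 (0.52 log units; beyond the scatter), a 7.5-fold lower number from compound 1 to compound 3 (0.88 log units; beyond the scatter) and a 2.3-fold lower number from compound 2 to compound 3 (0.35 log units; beyond the scatter), all of them modest. Compound 4 `CC(C)(C)NC(=O)N1CCC[C@H]1C(=O)N1CCC(NS(=O)(=O)c2cc(S(=O)(=O)c3ccccc3)ccc2C(F)(F)F)CC1` differs from compound 3 at another place, ((tert-butyl)amino in place of tert-butyl on a carbonyl carbon), that is, (tert-butyl)amino in place of tert-butyl on a carbonyl carbon whose other neighbours are an amide-type nitrogen in a ring. Among the measured compounds shown here, no measured step touches this carbonyl carbon, so the three measured steps give only a sense of the scale on which changes at the outer end of this side chain have moved the numbers so far. With nothing in the measured pairs to argue for a shift either way, compound 4 is expected to stay close to compound 3 in this assay. The expected step is a 1.3-fold higher number from compound 3 to compound 4 (0.10 log units; within the scatter), a step that need not exceed the scatter. The estimate for compound 4 in this assay is 50 nM, with a range from 20 nM to 130 nM.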

Compound 4, half-maximal inhibitory concentration: 20 nM
The estimate for compound 4 lay 2.5-fold (0.40 log units) above the measured number; measured number inside the range.
By their numbers in this assay, from the lowest: compounds 4 and 3 (each within the scatter of the next); then compound 2; then compound 1.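

Among the compounds shown here, putting (tert-butyl)amino in place of tert-butyl on a carbonyl carbon whose other neighbours are an amide-type nitrogen in a ring is the first measured change at this place, and in this assay it gives a 2.0-fold lower number from compound 3 to compound 4 (0.30 log units; within the scatter); the extra nitrogen and the hydrogen-bond donor that enter with it therefore leave the number level with that of compound 3. For the compounds shown here, the new side chain, 1-((tert-butyl)carbamoyl)pyrrolidin-2-yl, also extends the whole-group comparisons, with a 4.5-fold lower number from compound 2 to compound 4 (0.65 log units; beyond the scatter) and a 15-fold lower number from compound 1 to compound 4 (1.18 log units; beyond the scatter), the latter being the first large step in this set. No measurement given here bears on the cause of these steps.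

The compounds shown leave open whether a tert-butoxy group or a methylamino group on this same carbonyl carbon would keep the number in the range of compound 3 and compound 4. They also leave open whether a small chain such as methyl or a ring such as cyclohexylamino could take the place of the tert-butyl end while holding that range.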